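Inverting one ring stereocentre: compound 2 to compound 3

The compounds below may be only part of what the source reports. "The series", "measured", "known", "first", "only" and "open" are said of these compounds alone.

In a functional assay on SMMC-7721 cells (Homo sapiens) for antiproliferative activity, read by MTT assay, with a stated time of 48 h (a higher number here means a weaker inhibitor, a lower number a stronger inhibitor), compound 1 `CC(C)=CCC[C@]1(C)/C=C/[C@@H](OC(=O)C=C(C)C)[C@](C)(O)/C=C/[C@H](O)/C(CO)=C\C1` gives > 40000 nM, which is a limit of the assay and not a number. For the measured compounds named here, compound 2 `CO[C@@H]1/C=C/[C@@](C)(O)[C@H](OC(=O)C=C(C)C)/C=C/[C@@](C)(CCC=C(C)C)C/C=C\1CO` gives 38800 nM, the only actual number available so far. Compound 3 `CO[C@H]1/C=C/[C@@](C)(O)[C@H](OC(=O)C=C(C)C)/C=C/[C@@](C)(CCC=C(C)C)C/C=C\1CO` is the next structure to be tested, and it stands to compound 2 as follows: the two compounds have the same atoms and bonds and differ only in configuration as drawn: 1 of 7 stereo elements differ; a stereocentre at a saturated ring carbon is drawn R in compound 2 and S in compound 3. Going by the values given here, no measured pair yet shows what a change of configuration does, so the expectation rests on compound 2 at 38800 nM alone. In this assay the expected change, a 1.1-fold lower number from compound 2 to compound 3 (0.04 log units; within the scatter), is none beyond the scatter, with neither direction favoured. A result reported only as a limit is also expected to be a real possibility. The estimate for compound 3 is 35000 nM, with an expected range from 15000 nM to 60000 nM.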

Compound 3, half-maximal inhibitory concentration: 38100 nM
Estimate against measurement, compound 3: 1.1-fold (0.04 log units) below; low and high end bracket the measured number.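

In this assay, for the compounds shown here, inverting the stereocentre at the saturated ring carbon gives the first reading of a configuration change, a 1.0-fold lower number from compound 2 to compound 3 (0.01 log units; within the scatter), so the R and S drawings at this position are not told apart at this level of activity. Compound 1 gives > 40000 nM, which is a limit of the assay and not a number. The step of an at least 1.0-fold lower number from compound 1 to compound 3 (0.02 log units; that floor lies within the scatter) is therefore only a floor, and it sets no size for the effect of methyl in place of hydrogen on an oxygen on a saturated carbon.

As far as these compounds go, whether a longer chain or an amine at this position would give a number clearly lower than these stays open. Small differences are hard to read in this set because the values lie close to the top of the assay's range: the limit of > 40000 nM in this assay, at which 1 of the 3 values shown sits.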